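Amide for Acid in a Series That Stays at the Limit

The source may report more compounds than this note shows. Statements on the series, on what has been measured and on what is new or still open speak of the compounds shown alone.

Compound 1 `O=C(O)c1cccc(CCCCCC(=O)N2CCOC2=O)c1` carries a carboxy group, and compound 2 `NC(=O)c1cccc(CCCCCC(=O)N2CCOC2=O)c1` differs from it by amino in place of hydroxy on a carbonyl carbon. In an assay on HEK293 cells for inhibition of N-acylethanolamine-hydrolyzing acid amidase (Rattus norvegicus), read by LC-MS, with a stated time of 30 min (a lower number here means a stronger inhibitor, a higher number a weaker inhibitor), compound 1 reaches only the limit of the assay, > 20000 nM. In this assay compound 2 likewise stops at the limit, > 20000 nM. The step that the two limits leave unreadable from compound 1 to compound 2 thus has no readable size, as both values rest at the limit of > 20000 nM in this assay, at which 3 of the 3 values shown sit. Compound 3 `O=C(O)c1ccc(CCCCCC(=O)N2CCOC2=O)cc1` has the same atoms as compound 1, joined differently; the difference between the two cores is not broken down here. In this assay compound 3 also sits at the limit, > 20000 nM. Compound 4 `NC(=O)c1ccc(CCCCCC(=O)N2CCOC2=O)cc1` is unmeasured and differs from compound 3 by amino in place of hydroxy on a carbonyl carbon, the same change at the same place. Because compound 3 rests at the limit of > 20000 nM in this assay, at which 3 of the 3 values shown sit, and the step that the two limits leave unreadable from compound 1 to compound 2 was unreadable, compound 4 is expected to stay at the limit, the step that the limit leaves unreadable from compound 3 to compound 4 estimated as within scatter. Compound 4 is therefore estimated at 30000 nM.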

Compound 4, half-maximal inhibitory concentration: > 20000 nM
Compound 4 was reported as a limit; the forecaster's own chance of this, stated with the estimate: 85%; the middle value is on the limit's open side.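

Going by these compounds alone, compound 4 stops at a limit in this assay, as compound 3 does, and no step between compound 3 and compound 4 can be read. The compounds shown leave open whether changing carboxy to carbamoyl alters inhibition at all, as none yields a number: the limit of > 20000 nM in this assay, at which 4 of the 4 values shown sit.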